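A Ring Amine in Place of the Hydrazine on Compound 1

This account rests on a few compounds, and the source may have more. Where it says the series, first, only, none or still open, it means among the compounds named here.

Compound 1 `N#Cc1c(NN)nc(SCc2nc3ccccc3[nH]2)nc1-c1ccccc1` holds the second highest of three numbers in a functional assay on HL-60 cells (Homo sapiens) for cytotoxicity, read by MTT assay, with a stated time of 3 days (a lower number here means a stronger inhibitor, a higher number a weaker inhibitor), where compound 1 gives 11.9 nM. Compound 2 `N#Cc1c(Nc2ccccn2)nc(SCc2nc3ccccc3[nH]2)nc1-c1ccccc1` gives 20 nM, and the step of a 1.7-fold higher number from compound 1 to compound 2 (0.23 log units; within the scatter) stays within the scatter. Compound 3 `N#Cc1c(NC(N)=S)nc(SCc2nc3ccccc3[nH]2)nc1-c1ccccc1` gives 5.81 nM; the steps of a 2.0-fold lower number from compound 1 to compound 3 (0.31 log units; beyond the scatter) and a 3.4-fold lower number from compound 2 to compound 3 (0.54 log units; beyond the scatter) are both modest. Compound 4 `N#Cc1c(-c2ccccc2)nc(SCc2nc3ccccc3[nH]2)nc1N1CCNCC1` differs from compound 1 by piperazin-1-yl in place of aminoamino on an aromatic carbon. Among the measured compounds shown here, no measured step removes the aminoamino group itself; the three measured steps only vary what hangs from it, and all are modest. A step of comparable size, in either direction or none beyond the scatter, is therefore expected for compound 4: a 1.3-fold higher number from compound 1 to compound 4 (0.10 log units; within the scatter). Compound 4 is estimated at 15 nM, within 5 nM to 50 nM.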

Compound 4, half-maximal inhibitory concentration: 4 nM
For compound 4 the middle estimate is 3.8-fold (0.57 log units) above the measured one; measured number outside the range, below it.
By their numbers in this assay, from the lowest: compounds 4 and 3 (each within the scatter of the next); then compounds 1 and 2 (each within the scatter of the next).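

In this assay, the piperazin-1-yl ring on this aromatic carbon, the first ring placed directly there, gives a 3.0-fold lower number from compound 1 to compound 4 (0.47 log units; beyond the scatter) and, against (pyridin-2-yl)amino, a 5.0-fold lower number from compound 2 to compound 4 (0.70 log units; beyond the scatter), so the position accepts a six-membered non-aromatic ring without loss. The step of a 1.5-fold lower number from compound 3 to compound 4 (0.16 log units; within the scatter) leaves the ring and the sulfur-bearing group unseparated. No evidence is available to explain these steps. The compounds shown leave open whether morpholin-4-yl, an oxygen-bearing ring, or open-chain dimethylamino would keep this number.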